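A Remote Side-Group Swap and the Acid Dissociation Constant

The source may report more compounds than this note shows. Statements on the series, on what has been measured and on what is new or still open speak of the compounds shown alone.

For the measured compounds named here, compound 3 `COc1cccc(CNCCCNc2ccnc3cc(CC(C)C)ccc23)c1O` stands level with compounds 1 and 2 on the numbers so far. In a physicochemical assay for acid dissociation, compound 3 gives 9.47. Compound 1 `COc1ccc(F)cc1CNCCCNc1ccnc2cc(Cc3ccc(F)cc3Cl)ccc12` gives 9.47, and compound 2 `COc1cccc(CNCCCNc2ccnc3cc(-c4ccc(F)cc4)ccc23)c1O` gives 9.47. Going by the values given here, the one measured step, no change at the digits printed from compound 2 to compound 3 (within the scatter), shows that exchanging this side group left the reading within the scatter. Compound 4 `COc1cccc(CNCCCNc2ccnc3cc(Cc4ccc(F)cc4Cl)ccc23)c1O` differs from compound 3 by 2-chloro-4-fluorophenyl in place of isopropyl on a saturated chain carbon bound to an aromatic carbon. Compound 1 already carries a 2-chloro-4-fluorophenyl group on a saturated chain carbon bound to an aromatic carbon and gives 9.47, the same reading. The expected step is therefore no change at the digits printed from compound 3 to compound 4 (within the scatter), nothing beyond the scatter. Compound 4 is expected to give 9.47, with a range from 9.2 to 9.75.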

Compound 4, acid dissociation constant: 9.47
Compound 4: the middle estimate sits on the measured number at the digits printed; the range from low to high includes it.
By their numbers in this assay, from the lowest: compounds 1, 2, 3 and 4 (each within the scatter of the next).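

In this assay, 2-chloro-4-fluorophenyl in place of isopropyl on a saturated chain carbon bound to an aromatic carbon gives no change at the digits printed from compound 3 to compound 4 (within the scatter), so 8 heavy atoms with an aromatic ring replace 3 without moving the reading beyond the scatter. The same holds for a second exchange of this side group, with no change at the digits printed from compound 2 to compound 4 (within the scatter), and for 2-hydroxy-3-methoxyphenyl in place of 5-fluoro-2-methoxyphenyl on a saturated chain carbon bound to an amine nitrogen, a new place for a change, with no change at the digits printed from compound 1 to compound 4 (within the scatter). No supporting information accounts for these readings.

Still open, on these data alone, is whether an amine or a carboxylic acid in place of 2-chloro-4-fluorobenzyl on the aromatic carbon would shift the reading beyond the scatter.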